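The compounds below may be only part of what the source reports. "The series", "measured", "known", "first", "only" and "open" are said of these compounds alone.

Working notes on the series. Of the compounds shown here, two sharing one core have been measured in a functional assay on RXF 393 cells (Homo sapiens) for inhibition, read by sulforhodamine B assay, with a stated time of 48 h; on this read-out higher numbers stand for weaker inhibition of growth and lower numbers for stronger inhibition of growth. Compound 1 `COc1cc(-c2nn(-c3cccc(NC(=O)c4cccc(C(F)(F)F)c4)c3)cc2-c2ccncc2)ccc1Cl` gives 3150 nM in this assay. Compound 2 `COc1cc(-c2nn(-c3cccc(NC(=O)Nc4ccc(Cl)c(C(F)(F)F)c4)c3)cc2-c2ccncc2)ccc1Cl` gives 6290 nM in this assay. Going by the values given here, of the two numbers so far, that of compound 2 stands at the top, but the step of a 2.0-fold higher number from compound 1 to compound 2 (0.30 log units; within the scatter) does not separate the pair, so no order between them can be claimed.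

The next compound, compound 3 `COc1cc(-c2nn(-c3cccc(NC(=O)c4ccccc4)c3)cc2-c2ccncc2)ccc1Cl`, differs from compound 2 in one place: phenyl in place of (4-chloro-3-(trifluoromethyl)phenyl)amino on a carbonyl carbon. Among the compounds with values here, only one measured step bears on this change, since compound 1 likewise carries an aryl group directly on the carbonyl carbon whose other neighbour is the amide-type nitrogen, and the step from compound 1 to compound 2 was within the scatter. A number for compound 3 near that of compound 1 is therefore expected in this assay, and the expected step is a 2.1-fold lower number from compound 2 to compound 3 (0.32 log units; beyond the scatter). Compound 3 is estimated at 3000 nM, with a range from 1000 nM to 9000 nM.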

Compound 3, concentration for total growth inhibition: 6340 nM
Estimate against measurement, compound 3: 2.1-fold (0.32 log units) below; low and high end bracket the measured number.
By their numbers in this assay, from the lowest: compounds 1, 2 and 3 (each within the scatter of the next).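

In this assay, hydrogen in place of trifluoromethyl on an aromatic carbon gives a 2.0-fold higher number from compound 1 to compound 3 (0.30 log units; within the scatter) and so does not separate the two compounds, which means that this group shows no readable contribution on the benzoyl-type aryl ring in this pair. The larger exchange of phenyl in place of (4-chloro-3-(trifluoromethyl)phenyl)amino on a carbonyl carbon gives a 1.0-fold higher number from compound 2 to compound 3 (0.00 log units; within the scatter) and so also stays within the scatter, even though it removes the amino nitrogen with its hydrogen-bond donor, the chlorine and the trifluoromethyl together. No evidence beyond these growth-inhibition numbers bears on this result.

From the compounds shown here alone, whether an amine or a carboxylic acid in place of the trifluoromethyl on that aromatic carbon would give a step beyond the scatter remains open. Going by these compounds, it also remains open whether a cyclohexyl group or a short alkyl chain in place of phenyl on the carbonyl carbon would do so, since every group on that carbon so far contains a six-membered aromatic ring of carbon only.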